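The source may report more compounds than this note shows. Statements on the series, on what has been measured and on what is new or still open speak of the compounds shown alone.

Measured in an ADME assay on LLC-PK1 cells (Sus scrofa) for permeability; a lower number here means that the compound crosses the layer more slowly, a higher number that the compound crosses the layer faster:
- compound 1 `Cn1cc(C(=O)Nc2ccc(-c3ccccc3)c(C(F)(F)F)c2)c(=O)c2ccccc21`: 1.2 10^-6 cm/s
- compound 2 `Cn1cc(C(=O)Nc2ccc(-c3ccccn3)c(C(F)(F)F)c2)c(=O)c2cnccc21`: 16 10^-6 cm/s
- compound 3 `Cn1cc(C(=O)Nc2ccc(-c3ccncc3)c(C(F)(F)F)c2)c(=O)c2ccccc21`: 15 10^-6 cm/s

Compound 2 and compound 3 sit level within the scatter, and the numbers of both lie well beyond that of compound 1.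

Going to compound 4 `Cn1cc(C(=O)Nc2ccc(-c3ccccc3)c(C(F)(F)F)c2)c(=O)c2cnccc21`, phenyl takes the place of pyridin-2-yl on an aromatic carbon, ortho to a trifluoromethyl group: phenyl in place of pyridin-2-yl on an aromatic carbon. Going by the values given here, the only measured step that bears on this is a 13-fold higher number from compound 1 to compound 3 (1.10 log units; beyond the scatter), a large one, with pyridin-4-yl in place of phenyl. The new change runs the opposite way, with a different pyridine attachment and on the core of compound 2. One step is thin support, so a lower number but a smaller change is expected in this assay. The expected change is a 4.0-fold lower number from compound 2 to compound 4 (0.60 log units; beyond the scatter). For compound 4 the estimate is 4 10^-6 cm/s, with an expected range of 1.3 10^-6 cm/s to 13 10^-6 cm/s.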

Compound 4, apparent permeability in the LLC-PK1 assay: 5.7 10^-6 cm/s
For compound 4 the middle estimate is 1.4-fold (0.15 log units) below the measured one; low and high end bracket the measured number.
By their numbers in the LLC-PK1 assay, from the lowest: compound 1; then compound 4; then compounds 3 and 2 (each within the scatter of the next).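

On the core of compound 2, a ring without nitrogen at this position again goes with the lower number in the LLC-PK1 assay: a 2.8-fold lower number from compound 2 to compound 4 (0.45 log units; beyond the scatter), a modest step. Going by these compounds alone, the only earlier evidence was a 13-fold higher number from compound 1 to compound 3 (1.10 log units; beyond the scatter), a large step on another core with pyridin-4-yl, so the two sizes cannot be set against each other directly. In a physicochemical assay for solubility, in phosphate buffer, at pH 7.4 (on this read-out lower numbers stand for lower solubility and higher numbers for higher solubility), compound 2 gives < 1 ug/mL, which is a limit and not a number. In the physicochemical assay compound 4 gives < 1 ug/mL, which is also a limit and not a number. In the physicochemical assay the step from compound 2 to compound 4 cannot be read, as both values are limits: the limit of < 1 ug/mL in the physicochemical assay, at which 2 of the 2 values shown sit.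

Still open, on these data alone, is whether an amine or a carboxylic acid on this ring would bring the physicochemical assay off that limit. As far as these compounds go, how such a group would move the LLC-PK1 assay is also open.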